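Swapping chloro for bromo on the aryl ether of compound 1

The source may hold more compounds than are shown below. What is called first, only, known or untested is meant among the compounds shown, and "the series" means these compounds.

Compound 1 `NC1=NC2(CCOCC2)N(OCCCOc2cccc(Cl)c2)C(N)=N1` was tested in a functional assay on HCT-116 cells (Homo sapiens) for antiproliferative activity, read by MTT assay, with a stated time of 72 h (on this read-out higher numbers stand for weaker inhibition and lower numbers for stronger inhibition), where compound 1 gives 120 nM. Among the three measured compounds this is the highest number, that is, the weakest inhibition. Compound 2 `NC1=NC2(CCOCC2)N(OCCCOc2ccc(Cl)c(Cl)c2)C(N)=N1` gives 90 nM in this assay, and compound 3 `NC1=NC2(CCOCC2)N(OCCCOc2ccccc2Br)C(N)=N1` gives 30 nM. The step of a 1.3-fold lower number from compound 1 to compound 2 (0.12 log units; within the scatter) is within the scatter, so compounds 1 and 2 cannot be told apart. The step of a 4.0-fold lower number from compound 1 to compound 3 (0.60 log units; beyond the scatter) and the step of a 3.0-fold lower number from compound 2 to compound 3 (0.48 log units; beyond the scatter) are both modest but beyond the scatter.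

Compound 4 `NC1=NC2(CCOCC2)N(OCCCOc2cccc(Br)c2)C(N)=N1` differs from compound 1 by a single change: bromo in place of chloro on an aromatic carbon. Among the measured compounds shown here, none of the measured steps makes exactly this exchange. The closest is the step of a 1.3-fold lower number from compound 1 to compound 2 (0.12 log units; within the scatter), which also touches only one aromatic carbon and moved the number within the scatter; the larger steps toward compound 3 involve a different phenyl group altogether. Compound 4 is therefore expected to sit close to compound 1, with at most a small lowering, so the estimated step is a 1.3-fold lower number from compound 1 to compound 4 (0.12 log units; within the scatter). The estimate for compound 4 in this assay is 90 nM, with a range from 40 nM to 250 nM.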

Compound 4, half-maximal inhibitory concentration: 40 nM
Compound 4: the middle estimate sits 2.3-fold (0.35 log units) above what was measured; measured number inside the range.
By their numbers in this assay, from the lowest: compounds 3 and 4 (each within the scatter of the next); then compounds 2 and 1 (each within the scatter of the next).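

In this assay, among the compounds shown here, exchanging one halogen atom on this aromatic carbon matters more than the earlier compounds suggested: bromo in place of chloro gives a 3.0-fold lower number from compound 1 to compound 4 (0.48 log units; beyond the scatter), whereas adding a second chloro to the ring gave only a 1.3-fold lower number from compound 1 to compound 2 (0.12 log units; within the scatter). The 2-bromophenyl and 3-bromophenyl groups cannot be told apart, with a 1.3-fold higher number from compound 3 to compound 4 (0.12 log units; within the scatter), so the low number seen earlier for 2-bromophenyl is not confined to that one placing of the bromo. The 3-bromophenyl group also compares well with 3,4-dichlorophenyl, with a 2.3-fold lower number from compound 2 to compound 4 (0.35 log units; beyond the scatter), and among these four compounds, both bromo compounds give lower numbers than both chloro compounds, with no exception.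

Nothing available here explains why bromo and chloro differ in this way. From the compounds shown here alone, it also remains open whether the lowering continues with iodo, or whether a methyl or methoxy group on the same aromatic carbon would give a number like that of bromo or like that of chloro.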